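Swapping Chloro for Bromo on the Benzyl Ether Arm

This account rests on a few compounds, and the source may have more. Where it says the series, first, only, none or still open, it means among the compounds named here.

Compound 3 `O=c1c(O)c(-c2ccccc2)oc2cc(OCc3cccc(Cl)c3)cc(O)c12` was tested in an ADME assay on Huh-5-2 cells (Homo sapiens) for cytotoxicity, read by WST assay, with a stated time of 3 days; on this read-out lower numbers stand for higher toxicity in this test and higher numbers for lower toxicity in this test. For compound 3 this assay reports only a limit, > 100000 nM. Compound 1 `O=c1c(O)c(-c2ccccc2)oc2cc(OCc3ccccc3Br)cc(O)c12` also reaches only a limit, > 100000 nM. Compound 2 `O=c1c(O)c(-c2ccccc2)oc2cc(OCc3ccccc3[N+](=O)[O-])cc(O)c12` gives a number, 32000 nM. Among the measured steps, an at least 3.1-fold higher number from compound 2 to compound 3 (0.49 log units; beyond the scatter), while an at least 3.1-fold lower number from compound 1 to compound 2 (0.49 log units; beyond the scatter), and a step that the two limits leave unreadable from compound 1 to compound 3 since both values sit at the limit of > 100000 nM in this assay, at which 2 of the 3 values shown sit.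

Compound 4 `O=c1c(O)c(-c2ccccc2)oc2cc(OCc3cccc(Br)c3)cc(O)c12` differs from compound 3 by bromo in place of chloro on an aromatic carbon. Going by the values given here, no measured step swaps one halogen for another, and the one readable step concerns a nitro group, so this small exchange is expected to give a step that the limit leaves unreadable from compound 3 to compound 4. Compound 4 is therefore estimated at 150000 nM, within a range of 60000 nM to 400000 nM.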

Compound 4, half-maximal cytotoxic concentration: > 100000 nM
Compound 4: no number, only a limit; the forecaster's own chance of this, stated with the estimate: 80%; the middle value is on the limit's open side.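

In this assay compound 4 gives only a limit, > 100000 nM, so bromo in place of chloro on this aromatic carbon brings no readable change. The steps from compound 3 and from compound 1 to compound 4 cannot be read, because both ends of each are limits: the limit of > 100000 nM in this assay, at which 3 of the 4 values shown sit. What can be read is an at least 3.1-fold higher number from compound 2 to compound 4 (0.49 log units; beyond the scatter); the 2-nitrophenyl compound stays the only one of the four with a number rather than a limit.

Going by these compounds, how far apart the chloro and bromo compounds truly lie stays open. So does whether an amine or a carboxylic acid on this aromatic carbon would give a number at all.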